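This account rests on a few compounds, and the source may have more. Where it says the series, first, only, none or still open, it means among the compounds named here.

Compounds measured so far, all in a functional assay on PC-3 cells (Homo sapiens) for cytotoxicity, read by MTT assay, with a stated time of 72 h; on this read-out higher numbers stand for weaker inhibition and lower numbers for stronger inhibition:
compound 1 `COc1cc(Nc2nc3ccccc3nc2S(=O)(=O)c2ccc(C)cc2)cc(OC)c1` gives 2940 nM;
compound 2 `Cc1ccc(S(=O)(=O)c2nc3ccccc3nc2Nc2ccc(F)cc2)cc1` gives 13100 nM;
compound 3 `COc1ccc(S(=O)(=O)c2nc3ccccc3nc2Nc2cc(OC)cc(OC)c2)cc1` gives 6220 nM.

Among these three numbers compound 3 stands second highest. Its nearest neighbour is compound 2, whose number is higher than that of compound 3, and the gap between the two lies beyond the usual scatter. Its furthest neighbour is compound 1, reached by the step of a 2.1-fold higher number from compound 1 to compound 3 (0.33 log units; beyond the scatter), a change of methoxy in place of methyl on an aromatic carbon.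

Compound 4 `COc1ccc(S(=O)(=O)c2nc3ccccc3nc2Nc2ccc(F)cc2)cc1` differs from compound 3 in one place: 4-fluorophenyl in place of 3,5-dimethoxyphenyl on a nitrogen on an aromatic ring. The same exchange has already been made once within this set, from compound 1 to compound 2, where it gave a 4.5-fold higher number from compound 1 to compound 2 (0.65 log units; beyond the scatter). Going by the values given here, that step is the only direct guide, and it points to a modest move towards weaker inhibition.

In this assay compound 4 is therefore expected to show a step of about a 4.5-fold higher number from compound 3 to compound 4 (0.65 log units; beyond the scatter), a higher number than compound 3. The estimate for compound 4 is 28000 nM, with a range from 12000 nM to 65000 nM.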

Compound 4, half-maximal inhibitory concentration: 2200 nM
Compound 4: the middle estimate sits 13-fold (1.10 log units) above what was measured; the measured number lies below the stated range.
By their numbers in this assay, from the lowest: compounds 4 and 1 (each within the scatter of the next); then compound 3; then compound 2.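

In this assay the exchange of 3,5-dimethoxyphenyl for 4-fluorophenyl on the nitrogen has no single effect: once methoxy replaces methyl on the aromatic carbon, its direction reverses (a 2.8-fold lower number from compound 3 to compound 4 (0.45 log units; beyond the scatter)), as the two matched steps show: the same change on two cores in this assay, a 4.5-fold higher number (0.65 log units; beyond the scatter) from compound 1 to compound 2 and a 2.8-fold lower number (0.45 log units; beyond the scatter) from compound 3 to compound 4, 13-fold (1.10 log units) apart, beyond the scatter of two such steps.
The methoxy-for-methyl change also reverses when 4-fluorophenyl sits on the nitrogen (a 6.0-fold lower number from compound 2 to compound 4 (0.77 log units; beyond the scatter)), as its two matched steps show: the same change on two cores in this assay, a 2.1-fold higher number (0.33 log units; beyond the scatter) from compound 1 to compound 3 and a 6.0-fold lower number (0.77 log units; beyond the scatter) from compound 2 to compound 4, 13-fold (1.10 log units) apart, beyond the scatter of two such steps.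
In these four compounds, then, the effect of a change at either place depends on the group at the other, so neither can be scored alone.

Going by these compounds alone, only two groups have been compared at each place, so it remains open whether this dependence would persist with other groups. An amine on the aromatic ring attached to the nitrogen, or a longer chain such as ethoxy in place of methoxy, could test it.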